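Filling a vacant ring position on a pyridine-cored oxadiazole

This account rests on a few compounds, and the source may have more. Where it says the series, first, only, none or still open, it means among the compounds named here.

Compound 1 `Cc1cc(-c2c(C)nn(C)c2C)ccc1-c1nnc(N(C)Cc2ccc3nccn3c2)o1` gives > 31600 nM in an assay on COS-7 cells for inhibition of tyrosine-protein kinase receptor TYRO3 (Homo sapiens), read by ELISA, with a stated time of 1 h (a lower number here means a stronger inhibitor, a higher number a weaker inhibitor), a limit of the assay rather than a number.
Compound 2 `Cc1cc(-c2c(C)nn(C)c2C)cnc1-c1nnc(N(C)Cc2ccc3nccn3c2)o1` gives > 31600 nM, likewise a limit.
Compound 3 `Cc1cc(-c2c(C)nn(C)c2C)ccc1-c1nnc(N(C)Cc2ccc3ncc(-c4cnn(CCN(C)C)c4)n3c2)o1` gives 12600 nM.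

Compound 2 therefore stands at the weak end of what was measured: it shares with compound 1 the limit described by the limit of > 31600 nM in this assay, at which 2 of the 3 values shown sit, so only a ceiling is known for it, not a value. Compound 4 `Cc1cc(-c2c(C)nn(C)c2C)cnc1-c1nnc(N(C)Cc2ccc3ncc(-c4ccc(CN(C)C)cn4)n3c2)o1` arises from compound 2 by the change (5-((dimethylamino)methyl)pyridin-2-yl in place of hydrogen on an aromatic carbon). Among the compounds with values here, the one measured step that resembles this is the one from compound 1 to compound 3, where a group was put onto the same aromatic carbon of the shared core and gave an at least 2.5-fold lower number from compound 1 to compound 3 (0.39 log units; beyond the scatter), bringing that compound just inside the measurable range. Compound 4 adds a different group at the same spot, on the pyridine-containing core of compound 2, so a comparable modest gain is expected rather than a large one, with a real chance that only a limit is reported again. The step from compound 2 to compound 4 is thus estimated at an at least 2.1-fold lower number from compound 2 to compound 4 (0.32 log units; beyond the scatter), and compound 4 is expected to give about 15000 nM, plausibly between 5000 nM and 40000 nM.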

Compound 4, half-maximal inhibitory concentration in the tyrosine-protein kinase receptor TYRO3 assay: > 31600 nM
Compound 4: no number, only a limit (the forecaster's own chance of this, stated with the estimate: 35%); at least 2.1-fold (0.32 log units) between middle value and limit.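

In the tyrosine-protein kinase receptor TYRO3 assay compound 2 gives > 31600 nM, a limit of the assay rather than a number. Compound 4 gives > 31600 nM, likewise a limit of the assay rather than a number. The step between these two compounds therefore cannot be read: the limit of > 31600 nM in the tyrosine-protein kinase receptor TYRO3 assay, at which 3 of the 4 values shown sit. The compounds shown leave open how strongly either compound inhibits, and whether 5-((dimethylamino)methyl)pyridin-2-yl in place of hydrogen makes any difference to that inhibition. In a physicochemical assay for lipophilicity, at pH 7.4 (on this read-out higher numbers stand for higher lipophilicity and lower numbers for lower lipophilicity), compound 2 gives 2.8 and compound 4 gives 3, which is a number 0.20 log units higher from compound 2 to compound 4 (within the scatter).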